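Swapping the Aryl Ring for a Longer Heterocyclic Tail

This account rests on a few compounds, and the source may have more. Where it says the series, first, only, none or still open, it means among the compounds named here.

Compound 1 `CN(CCNCc1cn(-c2ccc(F)cc2)nn1)CCNc1ccnc2cc(Cl)ccc12` is the reference point. In a functional assay on HCC827 cells (Homo sapiens) for antiproliferative activity, read by sulforhodamine B assay, with a stated time of 72 h (a lower number here means a stronger inhibitor, a higher number a weaker inhibitor), compound 1 gives 19000 nM, the highest of the two numbers reported; compound 2 `CN(CCNCc1cn(-c2ccc(Cl)cc2)nn1)CCNc1ccnc2cc(Cl)ccc12` gives 9500 nM, and the step of a 2.0-fold lower number from compound 1 to compound 2 (0.30 log units; within the scatter) stays within the scatter. Compound 3 `CN(CCNCc1cn(CC(=O)O)nn1)CCNc1ccnc2cc(Cl)ccc12` yields no number but a limit of the assay: in this assay compound 3 gives > 200000 nM, which is the limit of > 200000 nM in this assay, at which 1 of the 3 values shown sits.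

The change to compound 4 `CN(CCNCc1cn(CCCn2nn[nH]c2=O)nn1)CCNc1ccnc2cc(Cl)ccc12` is a group of 9 heavy atoms (4 carbon, 4 nitrogen, 1 oxygen; one five-membered aromatic ring with 4 hetero atoms) in place of a group of 7 heavy atoms (6 carbon, 1 fluorine; one six-membered aromatic ring of carbon only), on an aromatic nitrogen. The measured steps that bear on it both replace the six-membered aromatic ring of carbon only on that aromatic nitrogen with a different group: an at least 10-fold higher number from compound 1 to compound 3 (1.02 log units; beyond the scatter) and an at least 21-fold higher number from compound 2 to compound 3 (1.32 log units; beyond the scatter). Both were large losses beyond the scatter, so a large rise in the number is expected for compound 4 as well, and there is a fair chance that only a limit will be reported. The estimate for compound 4 is 100000 nM, with a range from 30000 nM to 250000 nM. This estimate corresponds to an expected step of a 5.3-fold higher number from compound 1 to compound 4 (0.72 log units; beyond the scatter).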

Compound 4, half-maximal inhibitory concentration: > 200000 nM
Compound 4: only a limit was reported; the forecaster's own chance of this, stated with the estimate: 40%; at least 2.0-fold (0.30 log units) between middle value and limit.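

Compound 4 gives a limit and not a number in this assay: the limit of > 200000 nM in this assay, at which 2 of the 4 values shown sit. The loss seen with compound 3 therefore does not depend on the carboxymethyl group, since a tail ending in a five-membered aromatic ring with 4 hetero atoms also gives a large loss, with an at least 10-fold higher number from compound 1 to compound 4 (1.02 log units; beyond the scatter) and an at least 21-fold higher number from compound 2 to compound 4 (1.32 log units; beyond the scatter). Compound 3 and compound 4 both stand at a limit, so the step between them cannot be read and the two tails cannot be ranked.

The compounds shown leave open whether the loss follows from removing the six-membered aromatic ring of carbon only from the aromatic nitrogen or from what replaces it. A benzyl group or a plain propyl chain there, or a phenyl ring carrying a carboxylic acid, would help separate the two.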